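The source may hold more compounds than are shown below. What is called first, only, known or untested is meant among the compounds shown, and "the series" means these compounds.

The three measured compounds share one core. Compound 1 `COc1cccc(/C=C/C(=O)c2ccc(OC)c3c2OC(C)(C)C=C3)c1` carries a 3-methoxyphenyl group on the chain. In a functional assay on K562 cells (Homo sapiens) for antiproliferative activity, read by MTT assay, with a stated time of 24 h (on this read-out lower numbers stand for stronger inhibition and higher numbers for weaker inhibition), compound 1 gives > 10000 nM, which is a limit of the assay and not a number. Compound 2 `COc1ccc(C(=O)/C=C/c2ccc(F)cc2)c2c1C=CC(C)(C)O2` carries a 4-fluorophenyl group in place of that ring. In this assay compound 2 gives > 10000 nM, again a limit. Compound 3 `COc1ccc(C(=O)/C=C/c2ccc(-n3ccnc3)cc2)c2c1C=CC(C)(C)O2` carries a 1H-imidazol-1-yl group in place of fluoro. In this assay compound 3 gives > 10000 nM, also a limit. The two steps a step that the two limits leave unreadable from compound 1 to compound 2 and a step that the two limits leave unreadable from compound 2 to compound 3 cannot be sized because of the limit of > 10000 nM in this assay, at which 3 of the 3 values shown sit. Compound 3 therefore stands where every measured compound stands, at the limit, without a number that would rank it against the others.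

Compound 4 `COc1ccc(C(=O)/C=C/c2ccc([N+](=O)[O-])cc2)c2c1C=CC(C)(C)O2` differs from compound 3 by nitro in place of 1H-imidazol-1-yl on an aromatic carbon. The two measured steps bear on this change only in that neither could be read; they give no size and no direction. Compound 4 is expected to show no readable step beyond the scatter in this assay, and a step that the limit leaves unreadable from compound 3 to compound 4 is the estimated step. Compound 4 is estimated in this assay at 15000 nM, in a range from 5000 nM to 50000 nM, most probably reported once more as a limit.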

Compound 4, half-maximal inhibitory concentration: 7770 nM
Estimate against measurement, compound 4: 1.9-fold (0.29 log units) above; measured number inside the range.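

In this assay compound 4, with nitro on the aromatic carbon para to a large group, is the only one of the four compounds shown to give a number and not a limit, 7770 nM. Against the other three compounds the change reads as an at least 1.2-fold lower number from compound 3 to compound 4 (0.10 log units; that floor lies within the scatter), as an at least 1.2-fold lower number from compound 2 to compound 4 (0.10 log units; that floor lies within the scatter), and as an at least 1.2-fold lower number from compound 1 to compound 4 (0.10 log units; that floor lies within the scatter), so the data give only a floor for each step, and none of these floors clears the scatter. The true size of these steps stays open, and the steps among compound 1, compound 2 and compound 3 still cannot be read, because the other compounds all sit at the limit: the limit of > 10000 nM in this assay, at which 3 of the 4 values shown sit.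

From the compounds shown here alone, whether an amine, a nitrile or a carboxylic acid on that same aromatic carbon would also give a number in this assay remains open. Also open is whether nitro needs this place on the ring, since the compounds shown carry it at only one position and offer no second number to set beside that of compound 4.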